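The source may report more compounds than this note shows. Statements on the series, on what has been measured and on what is new or still open speak of the compounds shown alone.

Of the compounds shown here, two have been tested for toxicity toward host cells. Compound 1 `CCCc1ccc(Nc2nccs2)cc1OCC=C(C)C` gives a half-maximal cytotoxic concentration of 23000 nM in a functional assay on MT2 cells (Homo sapiens) for cytotoxicity; a lower number here means that less compound is tolerated, a higher number that more compound is tolerated. Compound 2 `CC(C)=CCOc1cc(Nc2ncccn2)ccc1Cl` gives 2500 nM in this assay, which is the lowest of the two numbers shown; the gap to compound 1 lies beyond the usual scatter, so compound 2 is the less well tolerated of the pair.

Compound 3 `COc1ccnc(Nc2ccc(Cl)c(OCC=C(C)C)c2)n1` is a close relative of compound 2. It differs in one place: methoxy in place of hydrogen on an aromatic carbon. Going by the values given here, no measured pair of compounds in this set shares that change, so its effect on tolerance cannot be read from any step already seen. Given the modest size of the added group, the step from compound 2 to compound 3 is expected to be small, a 1.6-fold higher number from compound 2 to compound 3 (0.20 log units; within the scatter), leaning toward a somewhat higher number. Compound 3 is therefore estimated to give about 4000 nM in this assay, within a range of 1500 nM to 12000 nM.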

Compound 3, half-maximal cytotoxic concentration: 9000 nM
Compound 3: middle estimate off by 2.3-fold (0.35 log units), on the low side, within the range that was stated.
By their numbers in this assay, from the lowest: compound 2; then compound 3; then compound 1.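

In this assay, going by these compounds alone, methoxy in place of hydrogen gives a 3.6-fold higher number from compound 2 to compound 3 (0.56 log units; beyond the scatter), the first step that can be read directly. It shows that this aromatic carbon, next to the ring nitrogen of the six-membered aromatic ring with 2 nitrogen, is not indifferent: an entering group of only 2 heavy atoms moves the number beyond the scatter, toward more compound being tolerated. Nothing available accounts for this shift.

The compounds shown leave open whether an amine, a hydroxyl or a longer alkoxy chain on this same carbon would move the number in the same direction or by a similar amount. They also leave open whether methoxy would have a similar effect on another carbon of this ring.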